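Swapping a Cyano for Phenyl on the Terminal Ring

The source may report more compounds than this note shows. Statements on the series, on what has been measured and on what is new or still open speak of the compounds shown alone.

Compound 1 `Cn1cncc1C(OCc1ccc(C#N)cc1-c1ccccc1)c1ccc(C#N)cc1` gives 140 nM
Compound 2 `Cn1cncc1C(OCc1ccc(C#N)cc1C#Cc1ccc(C#N)cc1)c1ccc(C#N)cc1` gives 11.6 nM

In a functional assay on NIH3T3 cells (Mus musculus) (on this read-out higher numbers stand for an effect only at larger amounts of compound and lower numbers for an effect already at smaller amounts), compound 2 has the lower of the two numbers. Compound 3 `Cn1cncc1C(OCc1ccc(C#N)cc1C#Cc1ccc(-c2ccccc2)cc1)c1ccc(C#N)cc1` carries phenyl in place of cyano on an aromatic carbon. Going by the values given here, one measured step bears on this change: a 12-fold lower number from compound 1 to compound 2 (1.08 log units; beyond the scatter), which brought in the 2-(4-cyanophenyl)ethynyl group and was large. Among the compounds with values here, no measured step alters the cyano alone, so the evidence is indirect, and a moderate rise is expected rather than a large one. The estimated change is a 2.6-fold higher number from compound 2 to compound 3 (0.41 log units; beyond the scatter). For compound 3 the expected value is 30 nM, within a range of 8 nM to 120 nM.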

Compound 3, half-maximal effective concentration: > 0.1 nM
Compound 3 was reported as a limit; the forecaster's own chance of this, stated with the estimate: 3%; the middle value is on the limit's open side.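

In this assay compound 3 is reported only as a limit, > 0.1 nM. The step from compound 2 to compound 3 therefore cannot be read. The compounds shown leave open how 4-phenylphenyl in place of 4-cyanophenyl shifts the number in this assay.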